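Compound 2 gives up its 1H-1,2,4-triazol-5-yl group

The source may report more compounds than this note shows. Statements on the series, on what has been measured and on what is new or still open speak of the compounds shown alone.

Among the measured compounds shown here, in a physicochemical assay for solubility, in phosphate buffer, with a stated time of 18 h (on this read-out higher numbers stand for higher solubility and lower numbers for lower solubility), compound 2 `CC(C)(C)c1nc(-c2ncn[nH]2)c2c(N)c(C#N)c(N)nc2n1` gives 64500 nM, the only true number so far. Compound 1 `CC(C)(C)c1nc(-c2ncc[nH]2)c2c(N)c(C#N)c(N)nc2n1` gives < 1000 nM, which is a limit of the assay and not a number. Compound 3 `CC(C)(C)c1nc(-c2nc(CO)cs2)c2c(N)c(C#N)c(N)nc2n1` keeps the shared core and carries 4-(hydroxymethyl)-1,3-thiazol-2-yl in place of 1H-1,2,4-triazol-5-yl on an aromatic carbon, (4-(hydroxymethyl)-1,3-thiazol-2-yl in place of 1H-1,2,4-triazol-5-yl on an aromatic carbon). For the measured compounds named here, only one measured step bears on this change, and it involves the same place: an at least 64-fold higher number from compound 1 to compound 2 (1.80 log units; beyond the scatter). On these data alone, this large step is bounded on one side by the limit of < 1000 nM in this assay, at which 1 of the 2 values shown sits, so its true size remains open. It shows that exchanging one five-membered aromatic ring for another at this place can move the read-out a long way, but it says nothing directly about the group entering here. A sizeable fall in this assay is therefore expected, with wide uncertainty, as compound 2 sits so far from the limit. The estimated step is an 8.1-fold lower number from compound 2 to compound 3 (0.91 log units; beyond the scatter), which would lie beyond the scatter. For compound 3 the expected value is 8000 nM, with an estimated range of 1500 nM to 40000 nM.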

Compound 3, solubility: < 1000 nM
Compound 3: a limit, no number; the forecaster's own chance of this, stated with the estimate: 15%; at least 8.0-fold (0.90 log units) between middle value and limit.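

In this assay, 4-(hydroxymethyl)-1,3-thiazol-2-yl in place of 1H-1,2,4-triazol-5-yl on an aromatic carbon gives an at least 64-fold lower number from compound 2 to compound 3 (1.80 log units; beyond the scatter), so a second group at this position, after 1H-imidazol-2-yl, falls far short of compound 2, and of the three compounds shown only compound 2 gives a true number. The value of compound 3 is a limit of the assay and not a number. The true size of this step therefore stays open, and the step between compound 1 and compound 3 cannot be read, because both of their values are limits: the limit of < 1000 nM in this assay, at which 2 of the 3 values shown sit.

The compounds shown leave open how far compound 1 and compound 3 actually lie from each other, and what the hydroxymethyl group contributes on its own, as the thiazole appears only with it in place. They also leave open where this assay would place the same thiazole carrying an amine or a carboxylic acid instead of the hydroxymethyl, or a 1H-1,2,3-triazol-4-yl ring at this position.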